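Cyclopropyl amide on a fluorophenyl core: expected lipophilicity

The compounds below may be only part of what the source reports. "The series", "measured", "known", "first", "only" and "open" are said of these compounds alone.

Four compounds share one core that carries two amide groups. Compound 1 `CNC(=O)c1cc(C(=O)N[C@H]2[C@@H]3COC[C@@H]32)cc2c1OC[C@H]2c1ccccc1` and compound 2 `CNC(=O)c1cc(C(=O)NC2CC2)cc2c1OC[C@H]2c1ccccc1` have a phenyl on the core; compound 3 `CNC(=O)c1cc(C(=O)N[C@H]2[C@@H]3COC[C@@H]32)cc2c1OC[C@H]2c1ccc(F)cc1` and compound 4 `CNC(=O)c1cc(C(=O)NC2CC2)cc2c1OC[C@H]2c1ccc(F)cc1` have a fluorophenyl there. In a physicochemical assay for lipophilicity, at pH 7.4 (a higher number here means a more lipophilic compound, a lower number a more polar compound), compound 1 gives 3.3, compound 2 gives 3.6 and compound 3 gives 3.6. Compound 4 is not yet measured.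

From compound 1 to compound 2 the change is a group of 3 heavy atoms (3 carbon; one three-membered non-aromatic ring of carbon only) in place of a group of 6 heavy atoms (5 carbon, 1 oxygen; one three-membered non-aromatic ring of carbon only, one five-membered non-aromatic ring with 1 hetero atom), on an amide-type nitrogen, and in this assay it made a number 0.30 log units higher from compound 1 to compound 2 (within the scatter). The two cores differ by fluoro in place of hydrogen on an aromatic carbon, which gave a number 0.30 log units higher from compound 1 to compound 3 (within the scatter).

From compound 3 to compound 4 the change is a group of 3 heavy atoms (3 carbon; one three-membered non-aromatic ring of carbon only) in place of a group of 6 heavy atoms (5 carbon, 1 oxygen; one three-membered non-aromatic ring of carbon only, one five-membered non-aromatic ring with 1 hetero atom), on an amide-type nitrogen. The place it sits on is described in the same words in both cases, so this is the same change, only made on the fluorophenyl core.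

Compound 4 is therefore expected to show a number 0.30 log units higher from compound 3 to compound 4 (within the scatter), resting on compound 2, because a number 0.30 log units higher from compound 1 to compound 2 (within the scatter) was seen for the same change. With that, compound 4 is estimated to give 3.9 in this assay, between 3.6 and 4.2.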

Compound 4, distribution coefficient: 3.8
Compound 4: middle estimate off by 0.10 log units, on the high side; measured number inside the range.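

In this assay, putting cyclopropyl in place of the larger oxygen-containing group on the amide-type nitrogen gave a number 0.20 log units higher from compound 3 to compound 4 (within the scatter) on the fluorophenyl core and a number 0.30 log units higher from compound 1 to compound 2 (within the scatter) on the phenyl core. Likewise, fluoro in place of hydrogen on an aromatic carbon gave a number 0.20 log units higher from compound 2 to compound 4 (within the scatter) with the cyclopropyl amide and a number 0.30 log units higher from compound 1 to compound 3 (within the scatter) with the larger group. Both changes therefore point the same way on both partners, which fits a change that carries from one core to the other, but every step lies within the scatter, so these four compounds do not show that either change truly moves the number, and one pair of cores says nothing about any other core.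

On these data alone, whether the same holds for a longer chain, an amine or a carboxylic acid on that amide-type nitrogen, or for chloro in place of fluoro, stays open. Nothing measured here says why the numbers fall as they do.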